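A few compounds are considered here, and "the series" means these few. Any claim that something is new, unique, unknown or untested is made for them only; others in the source may bear on it.

Measured so far in a functional assay on U-87MG ATCC cells (Homo sapiens) for cytotoxicity, read by MTT assay, with a stated time of 72 h; a lower number here means a stronger inhibitor, a higher number a weaker inhibitor:
compound 1 `COc1cc2c(Oc3ccc(NC(=O)c4cc(-c5ccccc5)nc5ccccc45)cc3F)ccnc2cc1OCCCN1CCCCC1`: 1490 nM
compound 2 `COc1ccc(-c2cc(C(=O)Nc3ccc(Oc4ccnc5cc(OCCCN6CCCCC6)c(OC)cc45)c(F)c3)c3ccccc3n2)cc1`: 1360 nM
compound 3 `COc1cccc(-c2cc(C(=O)Nc3ccc(Oc4ccnc5cc(OCCCN6CCCCC6)c(OC)cc45)c(F)c3)c3ccccc3n2)c1`: "not determined" (no result reported)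

Compound 3 stands without a number in this assay; its nearest comparators, compound 1 and compound 2, sit close together. Compound 4 `COc1cc2c(Oc3ccc(NC(=O)c4cc(-c5ccc(F)cc5)nc5ccccc45)cc3F)ccnc2cc1OCCCN1CCCCC1` differs from compound 3 by 4-fluorophenyl in place of 3-methoxyphenyl on an aromatic carbon. Going by the values given here, the only measured step that bears on this position is a 1.1-fold lower number from compound 1 to compound 2 (0.04 log units; within the scatter), which shows that putting a methoxy onto the phenyl left the number essentially unchanged. With compound 3 unmeasured, the expectation for compound 4 rests on compound 1 and compound 2, and no shift beyond the scatter is expected from exchanging one substituent on this ring for another. Compound 4 is therefore expected to give 1400 nM, with a range of 600 nM to 3500 nM.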

Compound 4, half-maximal inhibitory concentration: 980 nM
For compound 4 the middle estimate is 1.4-fold (0.15 log units) above the measured one; the range from low to high includes it.
By their numbers in this assay, from the lowest: compounds 4, 2 and 1 (each within the scatter of the next).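

At the aromatic carbon next to the ring nitrogen, the phenyl substituent has still not moved the number in this assay: there is a 1.4-fold lower number from compound 2 to compound 4 (0.14 log units; within the scatter) and a 1.5-fold lower number from compound 1 to compound 4 (0.18 log units; within the scatter), both within the scatter. Fluoro thus joins methoxy and hydrogen on this phenyl, with compound 1, compound 2 and compound 4 forming one flat group. Nothing at hand bears on a cause for these small differences.

On these data alone, whether an amine or a carboxylic acid on this phenyl would give a step beyond the scatter remains open.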